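A few compounds are considered here, and "the series" means these few. Any claim that something is new, unique, unknown or untested is made for them only; others in the source may bear on it.

Of the compounds shown here, three have so far been measured in a functional assay on SF-268 cells (Homo sapiens) for antiproliferative activity, read by MTT assay, with a stated time of 96 h; on this read-out higher numbers stand for weaker inhibition and lower numbers for stronger inhibition.
Compound 1, `CN(C)c1ccc(N2C(=O)NC3(CSC4=C3C(=O)c3ncccc3C4=O)C2=O)cc1`, gives 950 nM.
Compound 2, `COc1ccc(N2C(=O)NC3(CSC4=C3C(=O)c3ncccc3C4=O)C2=O)cc1`, gives 650 nM.
Compound 3, `O=C1NNC(=O)C2(CSC3=C2C(=O)c2ncccc2C3=O)N1`, gives 4820 nM.

Compound 2 has the lowest number of the three, but its gap to compound 1 is small: the step of a 1.5-fold lower number from compound 1 to compound 2 (0.16 log units; within the scatter), methoxy in place of dimethylamino on an aromatic carbon, stays within the usual scatter of repeated measurements, so the two cannot be told apart on these numbers. Compound 3 gives a markedly higher number than compound 2.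

Compound 4, `O=C1C2=C(C(=O)c3ncccc31)C1(CS2)NC(=O)N(c2ccc(Cl)cc2)C1=O`, is still to be measured. It differs from compound 2 in one place: chloro in place of methoxy on an aromatic carbon. For the measured compounds named here, the only measured step that touches the same position is a 1.5-fold lower number from compound 1 to compound 2 (0.16 log units; within the scatter), and it lay within the scatter. Going by the values given here, no measured compound carries chloro at this position, so there is nothing to show whether a change there would move the number at all. The expectation in this assay is therefore a step of about no change at the digits printed from compound 2 to compound 4 (within the scatter), meaning no change beyond the scatter, with a wide range to allow for the unknown. Compound 4 is estimated at 650 nM, with a range from 250 nM to 1700 nM.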

Compound 4, half-maximal inhibitory concentration: 580 nM
For compound 4 the middle estimate is 1.1-fold (0.05 log units) above the measured one; the range from low to high includes it.
By their numbers in this assay, from the lowest: compounds 4, 2 and 1 (each within the scatter of the next); then compound 3.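

In this assay, the step of a 1.1-fold lower number from compound 2 to compound 4 (0.05 log units; within the scatter) lies within the scatter, and so does the step of a 1.6-fold lower number from compound 1 to compound 4 (0.21 log units; within the scatter), so compounds 1, 2 and 4 cannot be told apart at the aromatic carbon para to a large group. This adds a third kind of group at that place: chloro has a single heavy atom and no hydrogen-bond acceptor, whereas methoxy has two heavy atoms and a hydrogen-bond acceptor, yet this difference in make-up comes with no change in the number that can be read beyond the scatter, and across these three compounds, with none going against it, the choice among dimethylamino, methoxy and chloro leaves the number where it was. Nothing measured here explains why these three groups give numbers so close together.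

As far as these compounds go, whether a carboxylic acid or a longer chain such as butyl at the same place would move the number beyond the scatter remains open. Also open, from the compounds shown here alone, is whether hydrogen in place of chloro, with no group at all on that carbon, would leave the number within the scatter of compound 4.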